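Two Stereoisomers Against a Lung Cancer Cell Line

The source may report more compounds than this note shows. Statements on the series, on what has been measured and on what is new or still open speak of the compounds shown alone.

Compound 1 `CCCCCCC(C)/C(O)=C1\C(=O)[C@@H]([C@@H](C)O)N(C)C1=O` and compound 2 `C/C=C/CCCC(C)/C(O)=C1\C(=O)[C@H]([C@H](C)O)N(C)C1=O` were both tested in a functional assay on A549 cells (Homo sapiens) for inhibition, read by MTT assay, with a stated time of 24 h; a higher number here means a weaker inhibitor, a lower number a stronger inhibitor. In this assay compound 1 returns only a limit, > 100000 nM. In this assay compound 2 likewise returns only a limit, > 100000 nM. For the measured compounds named here, compound 2 therefore stands where every value so far stands, as the limit of > 100000 nM in this assay, at which 2 of the 2 values shown sit, records: at the limit, not at a measured number. The next compound, compound 3 `C/C=C/CCCC(C)/C(O)=C1\C(=O)[C@@H]([C@@H](C)O)N(C)C1=O`, keeps every atom and bond of compound 2; the difference is the two compounds have the same atoms and bonds; at least one stereo element is drawn with a configuration in one of them and without one in the other: 2 of 5 stereo elements differ; a stereocentre at a saturated ring carbon is drawn S in compound 2 and R in compound 3; a stereocentre at a saturated chain carbon is drawn S in compound 2 and R in compound 3. In its drawn configuration compound 3 matches compound 1, while its chain matches compound 2. Going by the values given here, no step between measured compounds is available, since both are limits. The step is expected to be a step that the limit leaves unreadable from compound 2 to compound 3, no shift beyond the scatter, because the evidence the limit of > 100000 nM in this assay, at which 2 of the 2 values shown sit, places both values at the limit. Compound 3 is estimated at 150000 nM, within 50000 nM to 500000 nM, most likely reported again only as a limit.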

Compound 3, half-maximal inhibitory concentration: > 100000 nM
Compound 3: a limit, no number; the forecaster's own chance of this, stated with the estimate: 85%; the middle value does not contradict the limit.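

Compound 3 gives only a limit in this assay, so no step can be read from compound 2 or from compound 1 to compound 3: the limit of > 100000 nM in this assay, at which 3 of the 3 values shown sit.

Whether the configuration at the two stereocentres, or prop-1-en-1-yl in place of propyl, alters inhibition in this assay stays open, with no measured number among these compounds.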